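Cyclohexyl in Place of Isopropyl on a Weak Compound

The source may hold more compounds than are shown below. What is called first, only, known or untested is meant among the compounds shown, and "the series" means these compounds.

Measured compounds:
Compound 1, `Cc1ccccc1NC(=O)N1CC=C(C(=O)NCc2ccc(NC(=O)CC(=O)O)cc2)[C@H]1C(C)C`, gives 250 nM in an assay on Jurkat cells for inhibition of integrin alpha-4/beta-1 (Homo sapiens); on this read-out lower numbers stand for stronger inhibition and higher numbers for weaker inhibition.
Compound 2, `Cc1ccccc1NC(=O)N1CC=C(C(=O)NCc2ccc(NC(=O)CC(=O)O)cc2)[C@@H]1C(C)C`, gives 110 nM.
Compound 3, `Cc1ccccc1NC(=O)Nc1ccc(CNC(=O)C2=CCN(C(=O)CC(=O)O)[C@H]2C(C)C)cc1`, gives > 1000 nM.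

The value of compound 3 is a limit of the assay, not a number, and it sits at the limit of > 1000 nM in this assay, at which 1 of the 3 values shown sits. Going by the values given here, the only measured step, a 2.3-fold lower number from compound 1 to compound 2 (0.36 log units; beyond the scatter), rests on the fact that compounds 1 and 2 differ only in the configuration as drawn and does not touch the substituent changed here. Compound 4, `Cc1ccccc1NC(=O)Nc1ccc(CNC(=O)C2=CCN(C(=O)CC(=O)O)[C@H]2C2CCCCC2)cc1`, differs from compound 3 by cyclohexyl in place of isopropyl on a saturated ring carbon. Among the compounds with values here, no measured step bears on this change, so the expectation leans on where compound 3 already stands. Compound 4 is expected at 2000 nM, with a range from 500 nM to 8000 nM. The estimated step is a step that the limit leaves unreadable from compound 3 to compound 4, likely again ending as a limit.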

Compound 4, half-maximal inhibitory concentration: > 1000 nM
Compound 4 was reported as a limit (the forecaster's own chance of this, stated with the estimate: 60%); the middle value lies beyond the limit too.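

No step from compound 3 to compound 4 can be read, because both values are limits rather than numbers: the limit of > 1000 nM in this assay, at which 2 of the 4 values shown sit.

The compounds shown leave open whether cyclohexyl or isopropyl gives stronger inhibition on the shared core.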